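This account rests on a few compounds, and the source may have more. Where it says the series, first, only, none or still open, it means among the compounds named here.

Three compounds share one core. Compound 1 `CN(C(=O)NC(=O)c1cccc(C(F)(F)F)c1)c1nc(C(F)(F)F)c(C(=O)N/N=C/c2cccc(C(F)(F)F)c2)s1` gives 8.16 ug/mL in a functional assay on A549 cells (Homo sapiens) for inhibition, read by MTT assay, with a stated time of 72 h; a lower number here means a stronger inhibitor, a higher number a weaker inhibitor; compound 2 `CN(C(=O)NC(=O)c1ccc(Cl)cc1Cl)c1nc(C(F)(F)F)c(C(=O)N/N=C/c2ccc(C(F)(F)F)cc2)s1` gives 9.4 ug/mL; compound 3 `CN(C(=O)NC(=O)c1cccc(C(F)(F)F)c1)c1nc(C(F)(F)F)c(C(=O)N/N=C/c2ccccc2C(F)(F)F)s1` gives 12.1 ug/mL. Compound 3 carries the highest of the three numbers, yet its neighbours sit close: compound 2 is nearest and compound 1 furthest, both within the scatter, so no order can be read among them. For the measured compounds named here, the one single-point step, a 1.5-fold higher number from compound 1 to compound 3 (0.17 log units; within the scatter), moved the trifluoromethyl on the phenyl joined to the double-bonded nitrogen and changed nothing beyond the scatter.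

Compound 4 `CN(C(=O)NC(=O)c1c(F)cccc1F)c1nc(C(F)(F)F)c(C(=O)N/N=C/c2ccccc2C(F)(F)F)s1` is not yet measured. Against compound 3 the difference is 2,6-difluorophenyl in place of 3-(trifluoromethyl)phenyl on a carbonyl carbon. Going by the values given here, no measured step touches this carbonyl carbon, and compound 2, which differs from the others in more than one place, still lies within the scatter of both. With every shown step so small, a change beyond the scatter is not expected; the step of a 1.0-fold lower number from compound 3 to compound 4 (0.00 log units; within the scatter) is estimated as flat. Compound 4 is therefore expected to give 12 ug/mL, between 6 ug/mL and 24 ug/mL.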

Compound 4, half-maximal inhibitory concentration: 17.9 ug/mL
Beside the measured number, compound 4's estimate is 1.5-fold (0.17 log units) below it, within the range that was stated.
By their numbers in this assay, from the lowest: compounds 1, 2, 3 and 4 (each within the scatter of the next, the first and the last beyond it).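

In this assay, the carbonyl carbon whose other neighbour is the amide-type nitrogen now has its first single-place step, a 1.5-fold higher number from compound 3 to compound 4 (0.17 log units; within the scatter), for 2,6-difluorophenyl in place of 3-(trifluoromethyl)phenyl. This position has thus joined the carbon with a double bond to nitrogen in giving a step within the scatter, here with a swap between two phenyl groups that count no hydrogen-bond donors, no hydrogen-bond acceptors and no net charge. Nothing available bears on why this step is so small.

Still open, as far as these compounds go, is what this carbonyl carbon does when it carries no fluorinated phenyl at all, for instance an amine or a longer alkyl chain. The compounds shown also leave open whether this swap would give a similar step with a different group on the carbon with a double bond to nitrogen.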